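This account rests on a few compounds, and the source may have more. Where it says the series, first, only, none or still open, it means among the compounds named here.

In a functional assay on A549 cells (Homo sapiens) for inhibition, read by MTT assay, with a stated time of 48 h (on this read-out lower numbers stand for stronger inhibition and higher numbers for weaker inhibition), compound 1 (`c1ccc(C(c2c[nH]c3ccccc23)c2c[nH]c3ccccc23)cc1`) gives 40000 nM on a shared core. Compound 2 (`COc1ccc(C(c2c[nH]c3ccc(Br)cc23)c2c[nH]c3ccc(Br)cc23)cc1`) gives 10000 nM and stands at the low end of the numbers, level with compound 3 (`COc1ccc(C(c2c[nH]c3ccc(Br)cc23)c2c[nH]c3ccc(Br)cc23)cc1OC`) at 12000 nM and clearly under compound 1. Compound 4 (`COc1ccc(OC)c(C(c2c[nH]c3ccc(Br)cc23)c2c[nH]c3ccc(Br)cc23)c1`) has not yet been measured. It differs from compound 2 by a single exchange (2,5-dimethoxyphenyl in place of 4-methoxyphenyl on a saturated chain carbon bound to two aromatic carbons) that puts 2,5-dimethoxyphenyl in place of 4-methoxyphenyl. Among the measured compounds shown here, the one measured step that bears on this concerns compound 3: a 1.2-fold higher number from compound 2 to compound 3 (0.08 log units; within the scatter) came with methoxy in place of hydrogen on an aromatic carbon. For the measured compounds named here, no measured compound carries the 2,5-dimethoxyphenyl group, so this single step is a thin guide. On that evidence, no step beyond the scatter is expected in this assay for this exchange, and no firm direction can be given. The estimated size is a 1.2-fold higher number from compound 2 to compound 4 (0.08 log units; within the scatter) and it stays small. Compound 4 is expected at 12000 nM with an estimated range from 6000 nM to 25000 nM on this read-out.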

Compound 4, half-maximal inhibitory concentration: 10000 nM
The estimate for compound 4 lay 1.2-fold (0.08 log units) above the measured number; the measured number falls inside the stated range.
By their numbers in this assay, from the lowest: compounds 2, 4 and 3 (each within the scatter of the next); then compound 1.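

Placing 2,5-dimethoxyphenyl in place of 4-methoxyphenyl on a saturated chain carbon bound to two aromatic carbons gave no change at the digits printed from compound 2 to compound 4 (within the scatter) in this assay, and placing it in place of 3,4-dimethoxyphenyl gave a 1.2-fold lower number from compound 3 to compound 4 (0.08 log units; within the scatter) in the same assay. Across compound 2, compound 3 and compound 4, this place thus carries 4-methoxyphenyl, 3,4-dimethoxyphenyl and 2,5-dimethoxyphenyl with no step beyond the scatter, whereas the earlier compounds offered only one such step and no exchange to 2,5-dimethoxyphenyl. Nothing available gives a reason for this level result.

Going by these compounds, whether an amine or a carboxylic acid on this phenyl ring, in place of methoxy, would move the number beyond the scatter remains open. So does the outcome of replacing the whole aryl group at this place with a longer chain.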